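The source may hold more compounds than are shown below. What is called first, only, known or untested is meant among the compounds shown, and "the series" means these compounds.

Measured so far:
- compound 1, `Cc1c(Nc2nc(N)c3c(C#N)c(N4CCC[C@H]4C)n(C)c3n2)cnn1[C@@H]1CCOC1`, gives 20 nM
- compound 2, `C[C@@H]1CCCN1c1[nH]c2ncnc(N)c2c1C#N`, gives 166 nM
- compound 3, `C[C@@H]1CCCN1c1c(C#N)c2c(N)nc(Nc3cn(C)nc3Cl)nc2n1C`, gives 34 nM

All three numbers come from an assay on isolated protein for inhibition of Leucine-rich repeat serine/threonine-protein kinase 2 (Homo sapiens), read by TR-FRET and LanthaScreen, with stated times of 50 min and 30 min, in the presence of a further agent that is not named here; on this read-out lower numbers stand for stronger inhibition and higher numbers for weaker inhibition. Compound 3 stands second highest of the three. Its nearest neighbour is compound 1, whose number lies within the usual scatter of compound 3, so the two cannot be told apart. Compound 2 is the furthest, with a number beyond the scatter on the higher side, which here means weaker inhibition.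

The next compound, compound 4, is `Cc1c(Nc2nc(N)c3c(C#N)c(N4CCC[C@H]4C)n(C)c3n2)cnn1C1COC1`. It differs from compound 3 in one place:

5-methyl-1-(oxetan-3-yl)-1H-pyrazol-4-yl in place of 3-chloro-1-methyl-1H-pyrazol-4-yl on a nitrogen on an aromatic ring

Within the data shown here, no measured pair shows this change directly. Compound 1, which gives 20 nM, carries a closely related group in the same place as compound 4, and compound 3 gives 34 nM within the scatter of that. The step expected for compound 4 is therefore a 1.4-fold lower number from compound 3 to compound 4 (0.13 log units; within the scatter), none beyond the scatter. Compound 4 is expected at 25 nM, with a range from 10 nM to 60 nM.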

Compound 4, half-maximal inhibitory concentration: 47 nM
The estimate for compound 4 lay 1.9-fold (0.27 log units) below the measured number, and the stated range covers the measured number.
By their numbers in this assay, from the lowest: compounds 1, 3 and 4 (each within the scatter of the next, the first and the last beyond it); then compound 2.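

In this assay, the step of a 1.4-fold higher number from compound 3 to compound 4 (0.14 log units; within the scatter) lies within the usual scatter, so 5-methyl-1-(oxetan-3-yl)-1H-pyrazol-4-yl and 3-chloro-1-methyl-1H-pyrazol-4-yl cannot be told apart here, even though the entering group has more heavy atoms and an extra ring. The pair that differs only in the ring on the aromatic nitrogen says more: oxetan-3-yl in place of oxolan-3-yl gives a 2.4-fold higher number from compound 1 to compound 4 (0.37 log units; beyond the scatter), a modest step beyond the scatter and the first sign that the assay can distinguish these two rings. Nothing available explains either step.

This single pair cannot show a trend with ring size. An oxan-4-yl ring, a piperidin-4-yl ring or an open 2-methoxyethyl chain on that same nitrogen would test whether one exists.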